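The compounds below may be only part of what the source reports. "The series", "measured", "known", "first", "only" and "open" are said of these compounds alone.

Working notes on the sulfonyl quinoxaline series, cytotoxicity.

Compound 1 `O=S(=O)(c1ccc(Br)cc1)c1nc2ccccc2nc1N1CCCC1` is the bromo parent with pyrrolidin-1-yl. In a functional assay on PC-3 cells (Homo sapiens) for cytotoxicity, read by MTT assay, with a stated time of 72 h (on this read-out higher numbers stand for weaker inhibition and lower numbers for stronger inhibition), compound 1 gives only a limit, > 50000 nM. Compound 2 `O=S(=O)(c1ccc(F)cc1)c1nc2ccccc2nc1N1CCCC1` differs by fluoro in place of bromo on an aromatic carbon; in this assay compound 2 gives 12400 nM. That change made an at least 4.0-fold lower number from compound 1 to compound 2 (0.60 log units; beyond the scatter). Compound 3 `O=S(=O)(c1ccc(Br)cc1)c1nc2ccccc2nc1N1CCc2ccccc2C1` carries 1,2,3,4-tetrahydroisoquinolin-2-yl in place of pyrrolidin-1-yl on an aromatic carbon relative to compound 1. In this assay compound 3 gives only a limit, > 50000 nM. The step that the two limits leave unreadable from compound 1 to compound 3 cannot be read because the limit of > 50000 nM in this assay, at which 2 of the 3 values shown sit, caps both values.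

Compound 4 `O=S(=O)(c1ccc(F)cc1)c1nc2ccccc2nc1N1CCc2ccccc2C1` is to be measured in this assay. It differs from compound 3 by fluoro in place of bromo on an aromatic carbon, the same change as from compound 1 to compound 2, at the same place. The expectation is an at least 2.0-fold lower number from compound 3 to compound 4 (0.30 log units; that floor lies within the scatter), resting on the at least modest lowering seen in an at least 4.0-fold lower number from compound 1 to compound 2 (0.60 log units; beyond the scatter) applied to the limit of compound 3, > 50000 nM. Compound 4 is estimated at 25000 nM, within 8000 nM to 60000 nM, with a real chance that only a limit is again reported.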

Compound 4, half-maximal inhibitory concentration: 9230 nM
The estimate for compound 4 lay 2.7-fold (0.43 log units) above the measured number, within the range that was stated.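

In this assay, fluoro in place of bromo on an aromatic carbon gave an at least 5.4-fold lower number from compound 3 to compound 4 (0.73 log units; beyond the scatter), so the lowering seen on the core of compound 1 also appears on the core of compound 3, and the two steps compare as follows: the same change on two cores in this assay, an at least 4.0-fold lower number (0.60 log units; beyond the scatter) from compound 1 to compound 2 and an at least 5.4-fold lower number (0.73 log units; beyond the scatter) from compound 3 to compound 4; the limit leaves it open whether they differ It does not give the true size of the change on either core, as both bromo compounds give only a limit: the limit of > 50000 nM in this assay, at which 2 of the 4 values shown sit. With fluoro in place, 1,2,3,4-tetrahydroisoquinolin-2-yl in place of pyrrolidin-1-yl gives a 1.3-fold lower number from compound 2 to compound 4 (0.13 log units; within the scatter), which shows no separation of these two groups, while the matching step between the bromo compounds cannot be read.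

Still open, from the compounds shown here alone, is whether chloro or methoxy in the same place would behave like fluoro or like bromo. Also open, going by these compounds, is whether the change carries over in the same way to a core bearing morpholin-4-yl or diethylamino in place of pyrrolidin-1-yl.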